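A few compounds are considered here, and "the series" means these few. Any claim that something is new, unique, unknown or untested is made for them only; others in the source may bear on it.

Compound 1 `CCCn1c(=O)[nH]c2nc(-c3ccc(S(=O)(=O)N4CCN(c5ccc(Br)cc5)CC4)cc3)[nH]c2c1=O`: 29%
Compound 2 `CCCn1c(=O)[nH]c2nc(-c3ccc(S(=O)(=O)N4CCN(c5ccccc5)C(C)C4)cc3)[nH]c2c1=O`: -2%

In an assay on CHO cells for displacement of a labelled ligand from adenosine receptor A3 (Homo sapiens), read by scintillation counting, with a stated time of 45 min, tested at 1 uM, in the presence of a further agent that is not named here (a higher number here means more inhibition at the concentration tested (going by the name of the read-out), a lower number less inhibition), compound 1 gives 29%, the higher of the two numbers shown. Compound 2 gives -2%, a gap that lies beyond the usual scatter. Compound 3 `CCCn1c(=O)[nH]c2nc(-c3ccc(S(=O)(=O)N4CCN(c5ccccc5)CC4)cc3)[nH]c2c1=O` has not yet been measured in this assay. It differs from compound 1 by hydrogen in place of bromo on an aromatic carbon. Among the compounds with values here, no step between measured compounds covers this change. Because compound 2, which also carries the unsubstituted phenyl, shows -2%, a move downward is expected. The expected step is a number 19 percentage points lower from compound 1 to compound 3 (beyond the scatter), beyond the scatter. For compound 3 an inhibition of 10% is estimated, with a range from -10% to 28%.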

Compound 3, a percentage reported as inhibition, at one concentration (the size of the read-out at that concentration, not a potency): 27%
The estimate for compound 3 lay 17 percentage points below the measured number, and the stated range covers the measured number.
By their numbers in this assay, from the lowest: compound 2; then compounds 3 and 1 (each within the scatter of the next).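

In this assay, the change from 4-bromophenyl to phenyl is a step of a number 2 percentage points lower from compound 1 to compound 3 (within the scatter), so the bromo on this aromatic carbon is not needed for the inhibition seen at the concentration tested. The low number of compound 2 therefore does not go with its unsubstituted phenyl, but with the one other difference, hydrogen in place of methyl on a saturated ring carbon, a modest step of a number 29 percentage points higher from compound 2 to compound 3 (beyond the scatter). No measurement at hand accounts for either step.

Still open, going by these compounds, is whether an amine, a carboxylic acid or a methoxy group in place of the bromo would shift the number beyond the scatter. Also open, on these data alone, is whether a longer chain on that saturated ring carbon would act as the methyl does.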